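Hydroxy for chloro on the pendant phenyl of compound 3

The source may report more compounds than this note shows. Statements on the series, on what has been measured and on what is new or still open speak of the compounds shown alone.

Compound 3 `N#Cc1c(Cl)nc(SCC(=O)Nn2c(COc3ccc(Cl)cc3Cl)nc3ccccc3c2=O)nc1-c1ccc(Cl)cc1` gives 63.6% in a functional assay on the whole organism (strain albino) for inhibition, with Rattus norvegicus as the target, read by paw edema, with a stated time of 1 h, at a dose of 100 mg/kg by the oral route; on this read-out lower numbers stand for less inhibition and higher numbers for more inhibition at the one dose given (going by the name of the read-out). Among the three measured compounds it stands second highest on the numbers shown: compound 2 `N#Cc1c(Cl)nc(SCC(=O)Nn2c(COc3ccc(Cl)cc3Cl)nc3ccccc3c2=O)nc1-c1ccccc1` gives 60%, and compound 1 `Cn1c(SCC(=O)Nn2c(COc3ccc(Cl)cc3Cl)nc3ccccc3c2=O)nc(-c2ccc(O)cc2)c(C#N)c1=O` gives 80%; the gap to compound 2 is within the scatter, the gap to compound 1 beyond it.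

Compound 4 `N#Cc1c(Cl)nc(SCC(=O)Nn2c(COc3ccc(Cl)cc3Cl)nc3ccccc3c2=O)nc1-c1ccc(O)cc1` differs from compound 3 in one place: hydroxy in place of chloro on an aromatic carbon. Among the compounds with values here, the only measured single-point step, a number 3.6 percentage points higher from compound 2 to compound 3 (within the scatter), concerns the same aromatic carbon but exchanges hydrogen for chloro rather than chloro for hydroxy, so it bears on the present step only indirectly and was itself within the scatter. Within the data shown here, compound 1 carries the 4-hydroxyphenyl group, but it differs from compound 4 in the core as well, so no step is available for that pair; the number shows only that a member bearing 4-hydroxyphenyl, compound 1, can reach 80%.

A modest rise is therefore expected, a number 4.4 percentage points higher from compound 3 to compound 4 (within the scatter), with no assurance that it clears the scatter. Compound 4 is estimated at 68%, with a range from 55% to 80% in this assay.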

Compound 4, a percentage reported as inhibition, in the whole organism at one dose (the size of the read-out at that dose, not a potency): 72.7%
For compound 4 the middle estimate is 4.7 percentage points below the measured one, within the range that was stated.
By their numbers in this assay, from the lowest: compounds 2, 3, 4 and 1 (each within the scatter of the next, the first and the last beyond it).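

In this assay, the exchange of 4-chlorophenyl for 4-hydroxyphenyl gives a number 9.1 percentage points higher from compound 3 to compound 4 (within the scatter), so chloro and hydroxy on this aromatic carbon cannot be told apart at this dose, whereas the comparison with the unsubstituted phenyl gives a number 12.7 percentage points higher from compound 2 to compound 4 (beyond the scatter). Within the data shown here, this is the first step at this carbon to lie beyond the scatter, since the earlier exchange, a number 3.6 percentage points higher from compound 2 to compound 3 (within the scatter), gave no sign that a substituent here changes the read-out, and it shows that hydroxy in place of hydrogen at this position can register, though only modestly. Nothing measured on these compounds accounts for this difference.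

Going by these compounds, it remains open whether the difference from hydrogen is specific to hydroxy or would also appear with a methoxy group, an amine or a carboxylic acid on the same carbon. It is also open whether the hydroxy-for-hydrogen step would hold at other doses and times, or on the core of compound 1, since the compounds shown offer no matched pair for that core.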